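Extending Compound 2 with a 4-Chlorophenyl Group

This account rests on a few compounds, and the source may have more. Where it says the series, first, only, none or still open, it means among the compounds named here.

Compound 1 `Cn1c(-c2ccc(NC(=O)CSc3nc4ccccc4o3)cc2)nc(-c2ccccc2)c1-c1ccccc1` and compound 2 `CN1CCN(CC(=O)Nc2ccc(-c3nc(-c4ccccc4)c(-c4ccccc4)n3C)cc2)CC1` share one core and differ in a single place. In a functional assay on HT-29 cells (Homo sapiens) for cytotoxicity, read by MTT assay, with a stated time of 24 h, tested at 32 ug/mL (a lower number here means a weaker effect, a higher number a stronger effect of the compound at the concentration tested), compound 1 gives 79.3% and compound 2 gives 49.1%, so compound 2 stands as the lower of the two numbers; the step is a number 30.2 percentage points lower from compound 1 to compound 2 (beyond the scatter) when 4-methylpiperazin-1-yl replaces (1,3-benzoxazol-2-yl)sulfanyl on a saturated chain carbon bound to a carbonyl carbon. Compound 3 `Cn1c(-c2ccc(NC(=O)CN3CCN(Cc4ccc(Cl)cc4)CC3)cc2)nc(-c2ccccc2)c1-c1ccccc1` is not yet measured and differs from compound 2 by 4-chlorophenyl in place of hydrogen on a saturated chain carbon bound to an amine nitrogen in a ring. Among the measured compounds shown here, no measured step touches this place: the only known step, a number 30.2 percentage points lower from compound 1 to compound 2 (beyond the scatter), changes a different part of the molecule, and its large size shows only that this region of the structure matters to the read-out. The expectation therefore rests mainly on compound 2 itself, with a wide range. Compound 3 is expected to give 55%, between 30% and 80%. This corresponds to an expected step of a number 5.9 percentage points higher from compound 2 to compound 3 (within the scatter).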

Compound 3, a percentage reported as activity, at one concentration (the size of the read-out at that concentration, not a potency): 55.6%
Beside the measured number, compound 3's estimate is 0.6 percentage points below it; the range from low to high includes it.
By their numbers in this assay, from the lowest: compounds 2 and 3 (each within the scatter of the next); then compound 1.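

The earlier step changed the whole group on the carbon bound to the carbonyl carbon, whereas this one tests a different place, the saturated chain carbon bound to an amine nitrogen in a ring. In this assay the swap of methyl for 4-chlorobenzyl gives a number 6.5 percentage points higher from compound 2 to compound 3 (within the scatter) and so leaves the two numbers indistinguishable, even though 7 heavy atoms enter. At this single concentration, then, this place accepts a large aromatic group without a measurable difference in the read-out, and no evidence available here explains why.

On these data alone, whether the chlorine contributes anything remains open, since a plain phenyl or a 4-methoxyphenyl at this place would be needed to separate it from the ring. A carboxylic acid or a longer chain at the same carbon would show how far this tolerance extends.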